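A few compounds are considered here, and "the series" means these few. Any claim that something is new, unique, unknown or untested is made for them only; others in the source may bear on it.

In an assay on MDA-MB-231 cells for binding affinity to C-X-C chemokine receptor type 4 (Homo sapiens), read by fluorescence and microscopy, with stated times of 10 min and 30 min (on this read-out higher numbers stand for an effect only at larger amounts of compound and lower numbers for an effect already at smaller amounts), compound 1 `O=C(NCc1ccc(CNS(=O)(=O)c2cccc(C(F)(F)F)c2)cc1)c1ccc(F)cc1` gives 100 nM, and compound 2 `O=C(NCc1ccc(CNS(=O)(=O)c2ccc(CN3CCCC3)cc2)cc1)c1ccc(F)cc1` gives 1 nM, the lowest of the two numbers shown, with compound 1 standing higher on this read-out, a gap beyond the scatter. Compound 3 `O=C(NCc1ccc(CNS(=O)(=O)c2ccc(Cl)cc2)cc1)c1ccc(F)cc1` carries, relative to compound 2, the change (chloro in place of (pyrrolidin-1-yl)methyl on an aromatic carbon), on an aromatic carbon para to a large group. Without any measured step of this kind to lean on, compound 3 is expected to give a higher number than compound 2, a step of roughly a 30-fold higher number from compound 2 to compound 3 (1.48 log units; beyond the scatter). Compound 3 is therefore estimated at 30 nM, within a range from 5 nM to 300 nM.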

Compound 3, effective concentration (reported as EC, without a stated level of effect): 100 nM
Estimate against measurement, compound 3: 3.3-fold (0.52 log units) below, within the range that was stated.
By their numbers in this assay, from the lowest: compound 2; then compounds 1 and 3 (each within the scatter of the next).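

In this assay, chloro in place of (pyrrolidin-1-yl)methyl on this aromatic carbon gives a large step (a 100-fold higher number from compound 2 to compound 3 (2.00 log units; beyond the scatter)), so the number depends strongly on the group held here. 4-Chlorophenyl in place of 3-(trifluoromethyl)phenyl on the sulfonyl sulfur separates nothing (no change at the digits printed from compound 1 to compound 3 (within the scatter)). Nothing available explains either result. As far as these compounds go, it remains open whether a piperidine, a dimethylamine or a carboxylic acid on this carbon would keep the low number of compound 2, and whether a shorter or longer chain to the pyrrolidine would do the same.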